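A few compounds are considered here, and "the series" means these few. Any claim that something is new, unique, unknown or untested is made for them only; others in the source may bear on it.

Measured so far in an in vivo ADME assay on the whole organism (strain Mongrel) for metabolic stability, with Canis familiaris (Canis lupus familiaris) as the target; a lower number here means that the compound disappears faster, a higher number that the compound lasts longer:
compound 1, `C[C@@H](NC(=O)C1(NC(=O)c2cncc(Cl)n2)CC1)c1ccc(-n2nc(Cl)c3ccccc32)cc1F`: 15.1 h
compound 2, `C[C@@H](NC(=O)C1(NC(=O)c2cncc(Cl)c2)CC1)c1ccc(-n2nc(Cl)c3ccccc32)cc1F`: 6 h
compound 3, `C[C@@H](NC(=O)C1(NC(=O)c2cncs2)CC1)c1ccc(-n2nc(Cl)c3ccccc32)cc1F`: 4.3 h

Compound 3 gives the lowest of the three numbers. Its nearest neighbour is compound 2, and the two lie within the scatter of each other, as a 1.4-fold lower number from compound 2 to compound 3 (0.14 log units; within the scatter) shows. The furthest is compound 1, which stands beyond the scatter: a 3.5-fold lower number from compound 1 to compound 3 (0.55 log units; beyond the scatter). Compound 1 also stands above compound 2, see a 2.5-fold lower number from compound 1 to compound 2 (0.40 log units; beyond the scatter).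

Compound 4, `C[C@@H](NC(=O)C1(NC(=O)c2cncc(Br)c2)CC1)c1ccc(-n2nc(Cl)c3ccccc32)cc1F`, is the next member of the series. The change from compound 3 is 5-bromopyridin-3-yl in place of 1,3-thiazol-5-yl on a carbonyl carbon. Among the compounds with values here, the measured step that bears most directly on it is the one between compound 2 and compound 3, a 1.4-fold lower number from compound 2 to compound 3 (0.14 log units; within the scatter), since compound 4 carries a pyridinyl ring of the same kind as compound 2, with bromine where compound 2 has chlorine; read in reverse, that step would point to a small rise, within the scatter. Within the data shown here, no measured pair shows what bromine in place of chlorine does on this ring. The step from compound 3 to compound 4 in this assay is therefore expected to be a 1.5-fold higher number from compound 3 to compound 4 (0.18 log units; within the scatter), not beyond the scatter. For compound 4 the estimate in this assay is 6.5 h, with a range from 3 h to 14 h.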

Compound 4, half-life: 7.6 h
Compound 4: the middle estimate sits 1.2-fold (0.07 log units) below what was measured; low and high end bracket the measured number.
By their numbers in this assay, from the lowest: compounds 3, 2, 4 and 1 (each within the scatter of the next, the first and the last beyond it).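

In this assay the first pair differing only in the halogen on the pyridinyl ring gives a 1.3-fold higher number from compound 2 to compound 4 (0.10 log units; within the scatter) and so does not separate bromo from chloro on this aromatic carbon. The step of a 1.8-fold higher number from compound 3 to compound 4 (0.25 log units; within the scatter) likewise leaves 5-bromopyridin-3-yl and 1,3-thiazol-5-yl unresolved on the carbonyl carbon, as 5-chloropyridin-3-yl and 1,3-thiazol-5-yl already were. Within the data shown here, the step of a 2.0-fold lower number from compound 1 to compound 4 (0.30 log units; within the scatter) makes 5-bromopyridin-3-yl the first group here that is not separated from 6-chloropyrazin-2-yl, whereas 5-chloropyridin-3-yl and 1,3-thiazol-5-yl both stand beyond the scatter from it, although the bromo and chloro pyridinyl compounds cannot themselves be told apart.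

As far as these compounds go, whether an amine or a methoxy group in place of the halogen on the pyridinyl ring would keep the half-life in this range remains open. Nothing available accounts for any of these steps.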